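Exchanging the Aryl Group on the Amide Nitrogen

The source may report more compounds than this note shows. Statements on the series, on what has been measured and on what is new or still open speak of the compounds shown alone.

Compound 1 `O=C(CN1CCC(c2cccc[n+]2[O-])CC1)Nc1ccc(F)cc1` is the starting point of this account. Going by the values given here, in a functional assay on HEK293 cells for agonist activity at D(4) dopamine receptor (Homo sapiens), read by FLIPR (a higher number here means a larger maximal response, a lower number a smaller maximal response), compound 1 gives 71%, the second highest of the three numbers measured so far. Compound 2 `O=C(CN1CCC(c2cccc[n+]2[O-])CC1)Nc1cccc(-c2ccccc2)c1` gives 75% in this assay, and compound 3 `O=C(CN1CCC(c2cccc[n+]2[O-])CC1)Nc1ccc(F)cc1C(F)(F)F` gives 65%; the gap from compound 1 to either of them lies within the usual scatter, so no order among the three can be read from these numbers.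

Among the compounds with values here, the only measured step that changes a single place is a number 6 percentage points lower from compound 1 to compound 3 (within the scatter). It alters the same aryl group that is about to be replaced, and it left the maximal response essentially unchanged.

Compound 4 `O=C(CN1CCC(c2cccc[n+]2[O-])CC1)Nc1cccc(Cl)c1Cl` has not yet been measured. Compared with compound 1 it carries 2,3-dichlorophenyl in place of 4-fluorophenyl on an amide-type nitrogen.

Within the data shown here, the change in compound 4 is larger than the one from compound 1 to compound 3, since the whole aryl group is exchanged rather than a single substituent added, but the one comparison available on this ring shows a step within the scatter. The expectation for compound 4 in this assay is therefore a number 1 percentage points lower from compound 1 to compound 4 (within the scatter), a step that is not expected to exceed the scatter. Compound 4 is estimated to give 70%, with a range from 57% to 83%.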

Compound 4, largest response reached (reported as efficacy), in percent of the reference or control that the assay uses: 66%
The estimate for compound 4 lay 4 percentage points above the measured number; low and high end bracket the measured number.
By their numbers in this assay, from the lowest: compounds 3, 4, 1 and 2 (each within the scatter of the next).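

Exchanging 4-fluorophenyl for 2,3-dichlorophenyl on an amide-type nitrogen gives, in this assay, a number 5 percentage points lower from compound 1 to compound 4 (within the scatter). The earlier single-place step only added a trifluoromethyl group to the ring, whereas here the whole aryl group is replaced, and the maximal response still shows no change beyond the scatter. For this pair, the fluorine of compound 1 can therefore be lost and two chlorine atoms introduced without a readable effect on the maximal response in this assay. No information is available that would explain why the response holds across this exchange.

The compounds shown leave open whether this tolerance extends beyond aryl groups carrying halogen or a further phenyl ring, for example to a cyclohexyl group or a benzyl group on the same nitrogen, or to an aryl ring bearing an amine or a carboxylic acid. They also leave open whether any exchange at this place can move the maximal response beyond the scatter, since every step read so far stays within it.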